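The source may report more compounds than this note shows. Statements on the series, on what has been measured and on what is new or still open speak of the compounds shown alone.

Measured compounds:
- compound 1, `CN(C)CCn1cnnc1-c1cc(Oc2ccc(NC(=O)N/N=C/c3cccc(O)c3)cc2F)ccn1`
- compound 2, `CN(C)CCn1cnnc1-c1cc(Oc2ccc(NC(=O)N/N=C/c3ccc(Cl)cc3)cc2F)ccn1`
- compound 3, `CN(C)CCn1cnnc1-c1cc(Oc2ccc(NC(=O)N/N=C/c3ccc(F)cc3)cc2F)ccn1`

In a functional assay on A549 cells (Homo sapiens) for cytotoxicity, read by MTT assay, with a stated time of 72 h (a higher number here means a weaker inhibitor, a lower number a stronger inhibitor), compound 1 gives only a limit, > 100000 nM. In this assay compound 2 gives 780 nM, and compound 3 gives 1790 nM. Compound 2 therefore has the lowest of the two numbers, with a 2.3-fold higher number from compound 2 to compound 3 (0.36 log units; beyond the scatter) as the nearest gap.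

Compound 4, `COc1cc(/C=N/NC(=O)Nc2ccc(Oc3ccnc(-c4nncn4CCN(C)C)c3)c(F)c2)cc(OC)c1OC`, differs from compound 2 by 3,4,5-trimethoxyphenyl in place of 4-chlorophenyl on a carbon with a double bond to nitrogen. The group on this carbon matters a great deal: an at least 120-fold lower number from compound 1 to compound 2 (2.10 log units; beyond the scatter) and an at least 55-fold lower number from compound 1 to compound 3 (1.74 log units; beyond the scatter), whereas a 2.3-fold higher number from compound 2 to compound 3 (0.36 log units; beyond the scatter). Since a 3-hydroxyphenyl on this carbon sits at the limit (the limit of > 100000 nM in this assay, at which 1 of the 3 values shown sits), a move away from a halogenated phenyl is expected to raise the number, so a weaker inhibitor is estimated for compound 4, with a 7.7-fold higher number from compound 2 to compound 4 (0.89 log units; beyond the scatter). The estimate for compound 4 is 6000 nM, in the range 1000 nM to 60000 nM.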

Compound 4, half-maximal inhibitory concentration: > 100000 nM
Compound 4 was reported as a limit (the forecaster's own chance of this, stated with the estimate: 25%); middle value at least 16-fold (1.22 log units) away from the limit.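

Putting 3,4,5-trimethoxyphenyl in place of a halogenated phenyl on this carbon gives an at least 120-fold higher number from compound 2 to compound 4 (2.10 log units; beyond the scatter) and an at least 55-fold higher number from compound 3 to compound 4 (1.74 log units; beyond the scatter). So 3-hydroxyphenyl is not the only group that reaches the assay's upper limit, since a ring with three methoxy groups and no hydroxyl does too: the limit of > 100000 nM in this assay, at which 2 of the 4 values shown sit. The step from compound 1 to compound 4 cannot be read, as both values are limits. Open, from the compounds shown here alone, is how an unsubstituted phenyl or a 4-methoxyphenyl would behave on this carbon, and so whether the halogen itself is what keeps a measurable value in this assay.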